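Fluoro for trifluoromethoxy on a weakly cytotoxic urea

This account rests on a few compounds, and the source may have more. Where it says the series, first, only, none or still open, it means among the compounds named here.

Measured compounds:
- compound 1, `Cc1cc(C)nc(Oc2ccc(NC(=O)Nc3ccccc3)cc2)n1`: in a functional assay on CNE-2 cells (Homo sapiens) for cytotoxicity, read by MTT assay, with a stated time of 3 days (on this read-out higher numbers stand for weaker inhibition and lower numbers for stronger inhibition), compound 1 gives "not determined" (no result reported)
- compound 2, `Cc1cccc(NC(=O)Nc2ccc(Oc3nc(C)cc(C)n3)cc2)c1`: in this assay compound 2 gives "not determined" (no result reported)
- compound 3, `Cc1cc(C)nc(Oc2ccc(NC(=O)Nc3ccc(OC(F)(F)F)cc3)cc2)n1`: 30800 nM

Within the data shown here, compound 3 is the only compound of this group with a number in this assay; compounds 1 and 2 were made but carry no reported result, so compound 3 stands alone and cannot be ranked against them. Its value marks weak inhibition of cell growth.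

The next compound, compound 4, `Cc1cc(C)nc(Oc2ccc(NC(=O)Nc3ccc(F)cc3)cc2)n1`, differs from compound 3 in one place: fluoro in place of trifluoromethoxy on an aromatic carbon. Among the measured compounds shown here, no pair of measured compounds shows what this swap does here, so the size of the step is not known from the data. Given that compound 3 gives 30800 nM, only a modest shift is expected, if any, and the step from compound 3 to compound 4 is estimated as a 1.3-fold higher number from compound 3 to compound 4 (0.11 log units; within the scatter), which is small relative to the usual scatter. Compound 4 is therefore expected to give about 40000 nM, with a likely range from 12000 nM to 130000 nM.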

Compound 4, half-maximal inhibitory concentration: 46900 nM
For compound 4 the middle estimate is 1.2-fold (0.07 log units) below the measured one; the measured number falls inside the stated range.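

Among these compounds, in this series, compound 3 and compound 4 form the first measured pair that differs in one place. Replacing trifluoromethoxy, with 5 heavy atoms, by fluoro, with 1 heavy atom, on this aromatic carbon gives a 1.5-fold higher number from compound 3 to compound 4 (0.18 log units; within the scatter) in this assay and so leaves the two compounds indistinguishable on this read-out. Both values still mark weak inhibition of cell growth, and no evidence at hand bears on the reason for this result.

As far as these compounds go, it remains open whether a different kind of group at this position, such as an amine or a carboxylic acid, would shift the number beyond the scatter. From the compounds shown here alone, it is equally open whether fluoro and trifluoromethoxy would stay this close on a different core.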